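Notes: chloro in place of methyl, compound 3

The source may report more compounds than this note shows. Statements on the series, on what has been measured and on what is new or still open speak of the compounds shown alone.

- compound 1 `Cc1cc(C(F)(F)F)ccc1-c1cc2cnn([C@@H](CC(C)C)c3ccc(C(=O)NCCC(=O)O)cc3)c2cc1C`: 0.22 L/kg
- compound 2 `Cc1cc(C(F)(F)F)ccc1-c1cc2cn([C@@H](CC(C)C)c3ccc(C(=O)NCCC(=O)O)cc3)nc2cc1C`: 0.26 L/kg

In an ADME assay on the whole organism (Canis lupus familiaris) for pharmacokinetics (on this read-out lower numbers stand for narrower distribution and higher numbers for wider distribution into tissues), compound 1 gives 0.22 L/kg and compound 2 gives 0.26 L/kg. These two numbers lie within the usual scatter of each other, so compound 1 does not stand apart from compound 2.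

Compound 3 `Cc1cc2c(cnn2[C@@H](CC(C)C)c2ccc(C(=O)NCCC(=O)O)cc2)cc1-c1ccc(C(F)(F)F)cc1Cl` has not yet been measured. It differs from compound 1 in one place: chloro in place of methyl on an aromatic carbon. That place lies on a six-membered aromatic ring of carbon only, ortho to a large group and meta to a trifluoromethyl group. Cut one bond further out, 2-methyl-4-(trifluoromethyl)phenyl becomes 2-chloro-4-(trifluoromethyl)phenyl.

For the measured compounds named here, no measured pair in this set shows this change, so the data give no direct size for it. In this assay no step beyond the scatter is expected, in either direction. The estimate amounts to a 1.0-fold higher number from compound 1 to compound 3 (0.02 log units; within the scatter), which is expected to stay within the scatter. For compound 3 the expected value is 0.23 L/kg, with an estimated range from 0.14 L/kg to 0.38 L/kg.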

Compound 3, volume of distribution at steady state: 0.27 L/kg
Compound 3: the middle estimate sits 1.2-fold (0.07 log units) below what was measured; the range from low to high includes it.
By their numbers in this assay, from the lowest: compounds 1, 2 and 3 (each within the scatter of the next).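

In this assay, chloro in place of methyl on an aromatic carbon ortho to a large group gives a 1.2-fold higher number from compound 1 to compound 3 (0.09 log units; within the scatter), so the two compounds are not told apart on this read-out. Compound 1 and compound 2 both carry methyl at this place and held no reading of any exchange there; this pair gives the first one, and on it 2-chloro-4-(trifluoromethyl)phenyl serves as well as 2-methyl-4-(trifluoromethyl)phenyl in keeping the number where it was within the scatter. No measurement at hand offers an explanation for this result.

Going by these compounds, only methyl and chloro are seen at this place, so it remains open whether fluoro, methoxy, a nitrile or a longer chain such as ethyl or propyl would give a step beyond the scatter, and whether the same exchange reads alike on the other attachment of the core seen in compound 2. The carboxylic acid chain is the same in all three compounds, so nothing here speaks to a primary amide or a tetrazole in its place.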